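A Fluorine Added to the Phenyl Ring of Compound 2

A few compounds are considered here, and "the series" means these few. Any claim that something is new, unique, unknown or untested is made for them only; others in the source may bear on it.

For the measured compounds named here, compound 2 `C#CC(=O)N1C(c2ccccc2)SC[C@@H]1C(=O)OCC` stands lowest of the two numbers so far in a functional assay on MV cells (Homo sapiens) for inhibition, read by sulforhodamine B assay; a lower number here means a stronger inhibitor, a higher number a weaker inhibitor: in this assay compound 2 gives 400 nM. Going by the values given here, its only neighbour, compound 1 `C#CC(=O)N1C(c2ccc(C#N)cc2)SC[C@@H]1C(=O)OCC`, gives 2400 nM in this assay; that step, a 6.0-fold lower number from compound 1 to compound 2 (0.78 log units; beyond the scatter), came from a hydrogen in place of cyano on an aromatic carbon. Compound 3 `C#CC(=O)N1C(c2ccccc2F)SC[C@@H]1C(=O)OCC` differs from compound 2 by fluoro in place of hydrogen on an aromatic carbon, on an aromatic carbon of a six-membered aromatic ring of carbon only, ortho to a large group. Among the compounds with values here, the one measured step bears only loosely on this, since it removed a group from the same ring rather than adding fluorine, and it was modest. Within the data shown here, no measured compound carries fluorine. The expected step of a 1.3-fold higher number from compound 2 to compound 3 (0.10 log units; within the scatter) is therefore small, with no sure direction, likely within the scatter. Compound 3 is expected to give about 500 nM in this assay, with a range from 150 nM to 1600 nM.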

Compound 3, half-maximal inhibitory concentration: 1700 nM
The estimate for compound 3 lay 3.4-fold (0.53 log units) below the measured number, and the stated range ends below it.
By their numbers in this assay, from the lowest: compound 2; then compounds 3 and 1 (each within the scatter of the next).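

In this assay, fluoro in place of hydrogen, ortho to a large group, gives a 4.3-fold higher number from compound 2 to compound 3 (0.63 log units; beyond the scatter), so a change of just 1 heavy atom at this position is enough to move the number beyond the scatter. The earlier step, a 6.0-fold lower number from compound 1 to compound 2 (0.78 log units; beyond the scatter), involved a cyano group, and it could not show that a single fluorine would matter here. Compound 2, with its plain phenyl, now has the lowest number of the three, and both ring-substituted compounds give higher numbers, but no measurement here explains why this fluorine weakens inhibition.

From the compounds shown here alone, it remains open whether a chlorine, a methyl or a methoxy group at this same place would also raise the number. Going by these compounds, it is also open whether fluoro placed elsewhere on the ring would do the same.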